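Replacing Pyrazin-2-yl with 6-Aminopyridin-2-yl

The source may report more compounds than this note shows. Statements on the series, on what has been measured and on what is new or still open speak of the compounds shown alone.

Measured in a functional assay on HEK293 cells for agonist activity at Bombesin receptor subtype-3 (Homo sapiens), read by luminescence and calcium flux, with a stated time of 10 min; on this read-out higher numbers stand for an effect only at larger amounts of compound and lower numbers for an effect already at smaller amounts:
compound 1 `CCC(C)(C)Cc1c[nH]c(CCc2ccc(-c3ccncc3)cc2)n1` gives 305 nM
compound 2 `CCC(C)(C)Cc1c[nH]c(CCc2ccc(-n3cccn3)cc2)n1` gives 135 nM
compound 3 `CCC(C)(C)Cc1c[nH]c(CCc2ccc(-c3cnccn3)cc2)n1` gives 431 nM

Compound 3 has the highest of the three numbers, but its gap to compound 1 is within the scatter; only compound 2 lies clearly apart, as a 3.2-fold higher number from compound 2 to compound 3 (0.50 log units; beyond the scatter) shows. Compound 4 `CCC(C)(C)Cc1c[nH]c(CCc2ccc(-c3cccc(N)n3)cc2)n1` differs from compound 3 by one change: 6-aminopyridin-2-yl in place of pyrazin-2-yl on an aromatic carbon. Among the measured compounds shown here, the steps that bear on it are the earlier ring swaps at the same place, a 1.4-fold higher number from compound 1 to compound 3 (0.15 log units; within the scatter) and a 2.3-fold lower number from compound 1 to compound 2 (0.35 log units; beyond the scatter), both modest and pointing in opposite directions. For the measured compounds named here, no measured compound carries an amino group on that ring, so that part of the change has no precedent here. A step of about a 1.7-fold lower number from compound 3 to compound 4 (0.24 log units; within the scatter) in this assay is therefore expected, with wide uncertainty. Compound 4 is estimated at 250 nM, within a range of 70 nM to 900 nM.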

Compound 4, half-maximal effective concentration: 37 nM
Compound 4: the middle estimate sits 6.8-fold (0.83 log units) above what was measured; the whole stated range lies above it.
By their numbers in this assay, from the lowest: compound 4; then compound 2; then compounds 1 and 3 (each within the scatter of the next).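

In this assay, the group at this position can shift the number much further than the earlier ring swaps did, with a 12-fold lower number from compound 3 to compound 4 (1.07 log units; beyond the scatter). The 6-aminopyridin-2-yl ring also gives the lowest number of the set, with a 3.6-fold lower number from compound 2 to compound 4 (0.56 log units; beyond the scatter) and an 8.2-fold lower number from compound 1 to compound 4 (0.92 log units; beyond the scatter). Nothing available explains this gain.

The compounds shown leave open whether the amino group itself accounts for the step or the pyridine ring that carries it. A plain pyridin-2-yl ring, or a methyl group in place of the amine, would help separate the two.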